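The source may hold more compounds than are shown below. What is called first, only, known or untested is meant among the compounds shown, and "the series" means these compounds.

Compound 3 `CC(C)CCc1cn(-c2ccc(NC(=O)Nc3cccc(F)c3)cc2)nn1` carries an isopentyl chain on the shared core. In an assay for inhibition of ATP-dependent RNA helicase DDX3X (Homo sapiens), read by FRET, with a stated time of 40 min, in the presence of a further agent that is not named here (a lower number here means a stronger inhibitor, a higher number a weaker inhibitor), compound 3 gives 200 nM, the highest of the three numbers shown, though within the usual scatter of both others: compound 2 `CCCCc1cn(-c2cccc(S(=O)(=O)Nc3ccccc3OC)c2)nn1` gives 180 nM and compound 1 `CCCCc1cn(-c2cccc(S(=O)(=O)Nc3cccc4cnccc34)c2)nn1` gives 120 nM, and each of these carries a butyl chain on the core but differs from compound 3 elsewhere. Compound 4 `CCCCc1cn(-c2ccc(NC(=O)Nc3cccc(F)c3)cc2)nn1` is compound 3 with hydrogen in place of methyl on a saturated chain carbon bound to two saturated chain carbons, so its chain becomes the butyl seen in compounds 1 and 2. For the measured compounds named here, no measured pair isolates this change, so no step beyond the scatter is expected in either direction. The expected value for compound 4 is 170 nM, with a range from 70 nM to 400 nM. That estimate means a step of a 1.2-fold lower number from compound 3 to compound 4 (0.07 log units; within the scatter), expected to stay within the scatter.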

Compound 4, half-maximal inhibitory concentration: 600 nM
Compound 4: the middle estimate sits 3.5-fold (0.55 log units) below what was measured, outside the stated range (above it).
By their numbers in this assay, from the lowest: compounds 1, 2 and 3 (each within the scatter of the next); then compound 4.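

In this assay, going from isopentyl to butyl gives a 3.0-fold higher number from compound 3 to compound 4 (0.48 log units; beyond the scatter) and leaves the weaker inhibitor. For the compounds shown here, this pair differs in one place only, so it shows what the earlier compounds could not: the methyl on this saturated chain carbon matters for inhibition, at least on the core of compound 3. Nothing measured here explains the loss.

As far as these compounds go, whether a longer chain such as hexyl, or a cyclohexyl group, would give a lower number remains open. So does whether adding the same methyl to the butyl chain of compound 1 or compound 2 would have a similar effect.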